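The source may report more compounds than this note shows. Statements on the series, on what has been measured and on what is new or still open speak of the compounds shown alone.

Measured so far:
compound 1 `C=CC1C(=O)N(c2cc(OC)c(OC)c(OC)c2)C1c1ccc(OC)cc1`: 17 nM
compound 2 `COc1cc(N2C(=O)C(O)C2c2ccc(SC)cc2)cc(OC)c1OC`: 5 nM
compound 3 `CCSc1ccc(C2CC(=O)N2c2cc(OC)c(OC)c(OC)c2)cc1`: 141 nM

All three numbers come from a functional assay on MCF7 cells (Homo sapiens) for inhibition, read by resazurin assay, with a stated time of 72 h; on this read-out lower numbers stand for stronger inhibition and higher numbers for weaker inhibition. Among them compound 1 stands second highest; compound 2 sits lower and compound 3 higher, both gaps beyond the scatter. Compound 4 `COc1ccc(C2C(C3CC3)C(=O)N2c2cc(OC)c(OC)c(OC)c2)cc1` is not yet measured. It differs from compound 1 in one place: cyclopropyl in place of vinyl on a saturated ring carbon. Within the data shown here, no pair of measured compounds differs in a single place, so nothing measured resolves a change of this kind, and the step is set by expectation only. With two carbon heavy atoms leaving and three entering, no hydrogen-bond donors or acceptors involved, the expected step is a 1.2-fold higher number from compound 1 to compound 4 (0.07 log units; within the scatter), none beyond the scatter. Compound 4 is therefore estimated at 20 nM, in a range from 7 nM to 60 nM.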

Compound 4, half-maximal inhibitory concentration: 120 nM
Beside the measured number, compound 4's estimate is 6.0-fold (0.78 log units) below it; measured number outside the range, above it.
By their numbers in this assay, from the lowest: compound 2; then compound 1; then compounds 4 and 3 (each within the scatter of the next).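

In this assay this saturated ring carbon proves sensitive to a small, carbon-only change: cyclopropyl in place of vinyl gives a 7.1-fold higher number from compound 1 to compound 4 (0.85 log units; beyond the scatter), even though neither group carries hydrogen-bond donors or acceptors. The two groups are therefore not interchangeable at this position, at least in this single pair. Nothing available accounts for the step.

Going by these compounds, whether the step follows the added three-membered ring or the missing double bond stays open, and an ethyl group here would separate the two. On these data alone, how an amine or a longer chain would fare at this carbon also remains open.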